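From Amino to Dimethylamino on Compound 2

A few compounds are considered here, and "the series" means these few. Any claim that something is new, unique, unknown or untested is made for them only; others in the source may bear on it.

In a functional assay on HeLa cells (Homo sapiens) for antiproliferative activity, read by MTT assay, with a stated time of 48 h (on this read-out higher numbers stand for weaker inhibition and lower numbers for stronger inhibition), three related compounds have been measured so far. Compound 1 (`CCNCC(=O)Nc1cc(OC)ccc1C(=O)c1ccc(OC)c2c1OC(C)(C)C=C2`) reads 2690 nM and compound 3 (`C=C(c1ccc(OC)cc1NC(=O)CNC)c1ccc(OC)c2c1C=CC(C)(C)O2`) reads 500 nM while compound 2 (`C=C(c1ccc2c(c1)C=CC(C)(C)O2)c1ccc(OC)cc1NC(=O)CN`) reads 160 nM and so holds the lowest number of the three, with both gaps to it beyond the usual scatter of repeated measurements.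

The next compound to be considered, compound 4 (`C=C(c1ccc2c(c1)C=CC(C)(C)O2)c1ccc(OC)cc1NC(=O)CN(C)C`), alters compound 2 in a single place: dimethylamino stands in place of amino on a saturated chain carbon bound to a carbonyl carbon. The counted difference is this (dimethylamino in place of amino on a saturated chain carbon bound to a carbonyl carbon).

Among the measured compounds shown here, no two measured compounds differ in one place only, so the data offer no direct precedent for this change, and any forecast has to stay cautious. Since compound 2 at 160 nM is already the lowest of the set, a move toward a higher number seems likelier than a further drop. In this assay the expected step is modest and points toward weaker inhibition (a 2.2-fold higher number from compound 2 to compound 4 (0.34 log units; beyond the scatter)). Compound 4 is estimated to read about 350 nM (expected range 110 nM to 1100 nM).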

Compound 4, half-maximal inhibitory concentration: 640 nM
Estimate against measurement, compound 4: 1.8-fold (0.26 log units) below, and the stated range covers the measured number.
By their numbers in this assay, from the lowest: compound 2; then compounds 3 and 4 (each within the scatter of the next); then compound 1.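

In this assay, among the compounds shown here, a 4.0-fold higher number from compound 2 to compound 4 (0.60 log units; beyond the scatter) is the first step that can be read between two compounds differing in one place, so dimethylamino in place of amino on a saturated chain carbon bound to a carbonyl carbon now has a direct measured outcome: weaker inhibition, by a margin beyond the scatter. The change replaces 1 heavy atom and 1 hydrogen-bond donor with 3 heavy atoms and 0 hydrogen-bond donors, while each group has 1 hydrogen-bond acceptor, so this single step shows the added carbons and the lost donor arriving together and cannot tell their contributions apart. Nothing measured here accounts for the weaker inhibition.

On these data alone, compound 3 carries methylamino at the end of its chain but differs from compound 2 in more than one place, so the effect of that group alone on the core of compound 2 remains open. Also open, as far as these compounds go, is how larger amines at the same place, such as a pyrrolidine or a morpholine, or a carboxylic acid there, would read in this assay.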